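A hydroxy group added to compound 3: what to expect

The source may hold more compounds than are shown below. What is called first, only, known or untested is meant among the compounds shown, and "the series" means these compounds.

Three hydrazone compounds have been tested in an assay on isolated protein for inhibition of Maltase-glucoamylase (Homo sapiens), with a stated time of 15 min; a lower number here means a stronger inhibitor, a higher number a weaker inhibitor. Compound 1 `O=C(N/N=C/c1ccc(O)cc1)c1ccc(-c2nc3ccccc3s2)cc1` gives 11300 nM, compound 2 `O=C(N/N=C/c1ccc([N+](=O)[O-])cc1)c1ccc(-c2nc3ccccc3s2)cc1` gives 26400 nM, and compound 3 `COc1cccc(/C=N/NC(=O)c2ccc(-c3nc4ccccc4s3)cc2)c1` gives 11100 nM. Compound 3 stands at the low end of the three numbers, though a 1.0-fold lower number from compound 1 to compound 3 (0.01 log units; within the scatter) lies within the scatter, while a 2.4-fold lower number from compound 2 to compound 3 (0.38 log units; beyond the scatter). The move to compound 4 `COc1cc(/C=N/NC(=O)c2ccc(-c3nc4ccccc4s3)cc2)ccc1O` is hydroxy in place of hydrogen on an aromatic carbon. For the measured compounds named here, the one measured step that bears on this, a 1.0-fold lower number from compound 1 to compound 3 (0.01 log units; within the scatter), shows that swapping a hydroxy for a methoxy hardly moved this assay, so carrying both groups at once is expected to change little: a 1.2-fold lower number from compound 3 to compound 4 (0.09 log units; within the scatter). Compound 4 is therefore estimated at 9000 nM, with a range from 4000 nM to 20000 nM.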

Compound 4, half-maximal inhibitory concentration: 53300 nM
Compound 4: middle estimate off by 5.9-fold (0.77 log units), on the low side; measured number above the stated range.
By their numbers in this assay, from the lowest: compounds 3 and 1 (each within the scatter of the next); then compound 2; then compound 4.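

In this assay, a hydroxy group placed ortho to a methoxy group weakens inhibition (a 4.8-fold higher number from compound 3 to compound 4 (0.68 log units; beyond the scatter)), and a methoxy group added to the hydroxy-bearing ring does the same (a 4.7-fold higher number from compound 1 to compound 4 (0.67 log units; beyond the scatter)). The two groups together on one ring therefore do worse than either one alone, and worse even than the nitro group (a 2.0-fold higher number from compound 2 to compound 4 (0.31 log units; beyond the scatter)). Nothing measured here explains this result. On these data alone, whether an amine or a fluorine at this same position would weaken inhibition as well stays open. So does whether a longer chain in place of the methoxy group would change the outcome.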